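The source may hold more compounds than are shown below. What is called first, only, known or untested is meant among the compounds shown, and "the series" means these compounds.

Working notes on the series.

The shared core is that of compound 1 `CC(C)(C)c1ccc(C(=O)Nc2cccc(NC(=O)COc3ccc4c(=O)ccoc4c3)c2)cc1`, which in an assay on isolated protein for inhibition of Rho-associated protein kinase 1 (Homo sapiens), read by scintillation counting, radiometric assay and 33P incorporation, with a stated time of 40 min, in the presence of a further agent that is not named here (on this read-out lower numbers stand for stronger inhibition and higher numbers for weaker inhibition), gives 165 nM. Compound 2 `O=C(COc1ccc2c(=O)ccoc2c1)Nc1cccc(NC(=O)c2ccc(Br)cc2)c1` gives 303 nM in this assay. For the measured compounds named here, the single measured step, a 1.8-fold higher number from compound 1 to compound 2 (0.26 log units; within the scatter), changes the terminal ring only and stays within the scatter.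

Compound 3 `Cc1cc(NC(=O)COc2ccc3c(=O)ccoc3c2)cc(NC(=O)c2ccc(N(C)C)cc2)c1` carries a methyl on the central ring and a dimethylamino group on the terminal ring. In this assay compound 3 gives only a limit, > 10000 nM, not a number. Going by the values given here, compound 3 therefore sits at the edge of the measured range, (the limit of > 10000 nM in this assay, at which 1 of the 3 values shown sits), and no measured step connects it by a single change to compound 1 or compound 2.

Compound 4 `CN(C)c1ccc(C(=O)Nc2cc(Br)cc(NC(=O)COc3ccc4c(=O)ccoc4c3)c2)cc1` differs from compound 3 by bromo in place of methyl on an aromatic carbon. Among the compounds with values here, no measured step concerns this position of the central ring; the only step that involves bromo, a 1.8-fold higher number from compound 1 to compound 2 (0.26 log units; within the scatter), sits on the other ring and was within the scatter, so no movement beyond the scatter is expected in this assay. Compound 4 is therefore estimated at 8000 nM, with a range from 2000 nM to 30000 nM, and a further limit is a real possibility. The expected step is an at least 1.2-fold lower number from compound 3 to compound 4 (0.09 log units; that floor lies within the scatter).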

Compound 4, half-maximal inhibitory concentration: > 10000 nM
Compound 4 was reported as a limit (the forecaster's own chance of this, stated with the estimate: 55%); middle value at least 1.2-fold (0.09 log units) away from the limit.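

Compound 3 and compound 4 both give only a limit, so no step between them can be read: the limit of > 10000 nM in this assay, at which 2 of the 4 values shown sit.

The compounds shown leave open whether bromo in place of methyl on an aromatic carbon changes inhibition at all in this assay.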